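Thiophene in place of a bromophenyl on the chain

The source may hold more compounds than are shown below. What is called first, only, known or untested is meant among the compounds shown, and "the series" means these compounds.

Compound 1 `O=C(/C=C/c1cccs1)Nc1ccc2ncnc(Nc3cccc(Br)c3)c2c1`: 2.51 ug/mL
Compound 2 `O=C(/C=C/c1ccc(Br)cc1)Nc1ccc2ncnc(Nc3cccc(Cl)c3)c2c1`: 0.75 ug/mL
Compound 3 `O=C(/C=C/c1ccccc1Br)Nc1ccc2ncnc(Nc3cccc(Cl)c3)c2c1`: 1.65 ug/mL

In a functional assay on B16-F10 cells (Mus musculus) for inhibition, read by MTT assay, with a stated time of 48 h (a lower number here means a stronger inhibitor, a higher number a weaker inhibitor), compound 3 gives 1.65 ug/mL, the second highest of the three numbers; compound 1 lies within the scatter of it, while compound 2 sits beyond the scatter and lower. Compound 4 `O=C(/C=C/c1cccs1)Nc1ccc2ncnc(Nc3cccc(Cl)c3)c2c1` differs from compound 3 in one place: thiophen-2-yl in place of 2-bromophenyl on a double-bonded chain carbon bound to a double-bonded chain carbon. Within the data shown here, the only measured step, a 2.2-fold higher number from compound 2 to compound 3 (0.34 log units; beyond the scatter), shifts a bromine on the same kind of ring and does not test a thiophene at all. Compound 1 carries the thiophene together with a different halogen on the shared core, and in this assay compound 1 gives 2.51 ug/mL. Among the measured compounds shown here, no measured step bears directly on the change, so compound 4 is expected to land near compound 3, with a 1.2-fold higher number from compound 3 to compound 4 (0.08 log units; within the scatter) as the estimated step. Compound 4 is estimated at 2 ug/mL, between 0.8 ug/mL and 5 ug/mL.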

Compound 4, half-maximal inhibitory concentration: 4.26 ug/mL
Compound 4: the middle estimate sits 2.1-fold (0.33 log units) below what was measured, within the range that was stated.
By their numbers in this assay, from the lowest: compound 2; then compounds 3, 1 and 4 (each within the scatter of the next, the first and the last beyond it).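

In this assay, thiophen-2-yl weakens the compound beyond the scatter, whether it replaces 2-bromophenyl (a 2.6-fold higher number from compound 3 to compound 4 (0.41 log units; beyond the scatter)) or 4-bromophenyl (a 5.7-fold higher number from compound 2 to compound 4 (0.75 log units; beyond the scatter)), so this position on the chain does respond to the ring it carries. Chloro in place of bromo on an aromatic carbon stays within the scatter (a 1.7-fold higher number from compound 1 to compound 4 (0.23 log units; within the scatter)), so this pair of thiophene compounds reads alike with either halogen on the core. No evidence here explains the loss seen with the thiophene.

As far as these compounds go, how an unsubstituted phenyl ring would compare at this position remains open. So does the effect of an amine or a carboxylic acid on that ring.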